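Piperidin-1-yl replaces the side group of compound 3

A few compounds are considered here, and "the series" means these few. Any claim that something is new, unique, unknown or untested is made for them only; others in the source may bear on it.

- compound 1 `Cc1ccc(CNC(=O)c2cccc(C(C)Oc3ccnc(Nc4cnn(C5CCN(C)CC5)c4)c3)c2)cc1` gives 8900 nM
- compound 2 `Cc1ccc(CNC(=O)c2cccc(C(C)Oc3ccnc(NN4CCN(C)CC4)c3)c2)cc1` gives 8100 nM
- compound 3 `Cc1ccc(CNC(=O)c2cccc(C(C)Oc3ccnc(Nc4cnn(CC(C)(C)O)c4)c3)c2)cc1` gives > 100000 nM as a limit

In a functional assay on NCI-H3122 cells (Homo sapiens) for antiproliferative activity, read by MTT assay, with a stated time of 48 h (a lower number here means a stronger inhibitor, a higher number a weaker inhibitor), compound 3 has only a limit, not a number. Compound 4 `Cc1ccc(CNC(=O)c2cccc(C(C)Oc3ccnc(NN4CCCCC4)c3)c2)cc1` carries piperidin-1-yl in place of 1-(2-hydroxy-2-methylpropyl)-1H-pyrazol-4-yl on a nitrogen on an aromatic ring. Compound 2 at 8100 nM is the closest measured match and likewise has a non-aromatic ring on that nitrogen. The step of a 1.1-fold lower number from compound 1 to compound 2 (0.04 log units; within the scatter) is small, whereas an at least 12-fold higher number from compound 2 to compound 3 (1.09 log units; beyond the scatter) and an at least 11-fold higher number from compound 1 to compound 3 (1.05 log units; beyond the scatter) are both large. A large move to a lower number is therefore expected, and the estimated step is an at least 6.6-fold lower number from compound 3 to compound 4 (0.82 log units; beyond the scatter) in size. The estimate for compound 4 is 15000 nM (expected range 4000 nM to 60000 nM)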

Compound 4, half-maximal inhibitory concentration: 37400 nM
Compound 4: the middle estimate sits 2.5-fold (0.40 log units) below what was measured; measured number inside the range.
By their numbers in this assay, from the lowest: compounds 2 and 1 (each within the scatter of the next); then compound 4. At a limit, above all of these: compound 3.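

In this assay, changes at this nitrogen now give a graded picture: there is an at least 2.6-fold lower number from compound 3 to compound 4 (0.42 log units; beyond the scatter), but also a 4.6-fold higher number from compound 2 to compound 4 (0.66 log units; beyond the scatter) and a 4.2-fold higher number from compound 1 to compound 4 (0.62 log units; beyond the scatter). A non-aromatic ring on this nitrogen is therefore not enough on its own, as piperidin-1-yl and 4-methylpiperazin-1-yl give clearly different numbers. Compound 3 has only a limit, so the first step is a minimum: the limit of > 100000 nM in this assay, at which 1 of the 4 values shown sits.

Going by these compounds, it remains open whether the difference between compound 2 and compound 4 follows the methyl group or the second ring nitrogen. An unsubstituted piperazin-1-yl group or a morpholin-4-yl group would help separate the two.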